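The compounds below may be only part of what the source reports. "The series", "measured", "known", "first", "only" and "open" are said of these compounds alone.

Series notes, cytotoxicity.

In an ADME assay on HepG2 2.2.15 cells (Homo sapiens) for cytotoxicity, read by MTT assay, with stated times of 48 h and 9 days (a higher number here means that more compound is tolerated, a lower number that less compound is tolerated), compound 1 `COc1ccc2c(=O)c(/C=C/C(=O)Nc3cc(C)ccc3C)coc2c1` gives 1100000 nM.
In this assay compound 2 `COc1ccc(NC(=O)/C=C/c2coc3cc(OC)ccc3c2=O)cc1` gives 718000 nM.
In this assay compound 3 `COc1cccc(NC(=O)/C=C/c2coc3cc(OC)ccc3c2=O)c1` gives 1130000 nM.

Compound 1 stands second highest of the three numbers, but all three lie within the scatter of one another: a 1.5-fold lower number from compound 1 to compound 2 (0.19 log units; within the scatter), a 1.0-fold higher number from compound 1 to compound 3 (0.01 log units; within the scatter), and a 1.6-fold higher number from compound 2 to compound 3 (0.20 log units; within the scatter). Across the three, swapping one aryl group on the amide-type nitrogen for another has left the read-out in this assay essentially unchanged.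

Compound 4 `COc1ccc2c(=O)c(/C=C/C(=O)Nc3ccc(F)cc3)coc2c1` has not yet been measured. It differs from compound 1 in one place: 4-fluorophenyl in place of 2,5-dimethylphenyl on an amide-type nitrogen. The steps that bear on this change are the two that start from compound 1, both within the scatter, which together with the step from compound 2 to compound 3 suggest the aryl group on the amide-type nitrogen has little influence on the number in this assay among these compounds. No step beyond the scatter is therefore expected for compound 4, and the estimated step is a 1.1-fold lower number from compound 1 to compound 4 (0.04 log units; within the scatter). Compound 4 is expected to give about 1000000 nM in this assay, with a range of 500000 nM to 2000000 nM.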

Compound 4, half-maximal cytotoxic concentration: 743000 nM
For compound 4 the middle estimate is 1.3-fold (0.13 log units) above the measured one; low and high end bracket the measured number.
By their numbers in this assay, from the lowest: compounds 2, 4, 1 and 3 (each within the scatter of the next).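

In this assay 4-fluorophenyl on the amide-type nitrogen falls in with the other aryl groups there, as a 1.5-fold lower number from compound 1 to compound 4 (0.17 log units; within the scatter) and a 1.5-fold lower number from compound 3 to compound 4 (0.18 log units; within the scatter) both stay within the scatter. New here is a change of the substituent on an aromatic carbon alone, fluoro in place of methoxy, and a 1.0-fold higher number from compound 2 to compound 4 (0.01 log units; within the scatter) also stays within the scatter. No measurement among these compounds gives a reason for this insensitivity.

Open, as far as these compounds go, is whether an amine or a carboxylic acid on this aryl group, or a longer alkyl chain in place of the aryl group on the amide-type nitrogen, would also stay within the scatter. Also open, from the compounds shown here alone, is whether a change to the shared core would move the number in this assay beyond the scatter.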